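The source may hold more compounds than are shown below. What is called first, only, known or untested is meant among the compounds shown, and "the series" means these compounds.

The measured compounds and their values in an assay on HepG2 cells for activation of nuclear factor erythroid 2-related factor 2 (Homo sapiens), read by a luciferase reporter, with a stated time of 5 h; a lower number here means that less compound is needed, a higher number that more compound is needed for the effect:

compound 1, `COc1cccc(/C=C/c2ccc(F)cc2)c1`: 6000 nM
compound 2, `COc1cccc(/C=C/c2ccc(F)cc2)c1OC`: 2900 nM
compound 3, `COc1cccc(/C=C/c2ccccc2OC)c1`: 4400 nM

Compound 1 and compound 2 differ in one place. The change is methoxy in place of hydrogen on an aromatic carbon, and it gave a 2.1-fold lower number from compound 1 to compound 2 (0.32 log units; beyond the scatter) in this assay. Compound 3 carries a different core; how its core differs from that of compound 1 is not broken down here. Its value in this assay lies within the scatter of both compound 1 and compound 2, so no order among these three can be stated from it.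

Compound 4, `COc1cccc(/C=C/c2cc(OC)ccc2OC)c1`, has not yet been measured in this assay. It differs from compound 3 by methoxy in place of hydrogen on an aromatic carbon. This is the same kind of change as that from compound 1 to compound 2, though the surroundings are not the same: in compound 2 the entering group is ortho to a group of 9 heavy atoms and ortho to a methoxy group, whereas in compound 4 it is meta to a large group and para to a methoxy group. For the measured compounds named here, the only guide is the step of a 2.1-fold lower number from compound 1 to compound 2 (0.32 log units; beyond the scatter), which was modest and just beyond the scatter. Compound 4 is therefore expected to show a 1.8-fold lower number from compound 3 to compound 4 (0.25 log units; within the scatter) in this assay, a step of about the same size. The estimate for compound 4 is 2500 nM, with a likely range from 1200 nM to 6000 nM.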

Compound 4, half-maximal effective concentration: > 15000 nM
Compound 4 was reported as a limit (the forecaster's own chance of this, stated with the estimate: 5%); at least 6.0-fold (0.77 log units) between middle value and limit.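

Placed on the core of compound 3, methoxy in place of hydrogen on an aromatic carbon gave an at least 3.4-fold higher number from compound 3 to compound 4 (0.53 log units; beyond the scatter) in this assay, which runs opposite to the earlier step on the core of compound 1. Compound 4 stands at > 15000 nM, which is a limit of the assay and not a number, so only the direction of this step and its smallest size can be read: the limit of > 15000 nM in this assay, at which 1 of the 4 values shown sits. The change therefore cannot be carried as one fixed effect between these two cores, although a single pair on each core does not show whether the core or the place of the new methoxy decides the outcome: the same change on two cores in this assay, a 2.1-fold lower number (0.32 log units; beyond the scatter) from compound 1 to compound 2 and an at least 3.4-fold higher number (0.53 log units; beyond the scatter) from compound 3 to compound 4, at least 7.0-fold (0.84 log units) apart, beyond the scatter of two such steps.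

From the compounds shown here alone, it remains open whether a hydroxyl or an amine in the place taken by the new methoxy of compound 4, meta to a large group and para to a methoxy group, would also raise the number. Going by these compounds, it is equally open how the same methoxy change would behave on further cores.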